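From compound 3 to compound 4: a carbonyl substituent exchanged

The compounds below may be only part of what the source reports. "The series", "measured", "known", "first", "only" and "open" are said of these compounds alone.

So far, an ADME assay on Caco-2 cells (Homo sapiens) for permeability, in the apical to basolateral direction, at pH 7.4 (on this read-out higher numbers stand for higher permeability and lower numbers for lower permeability), gives these numbers:
compound 1 `Cc1ccc2[nH]c(C(=O)N[C@H]3CN(S(=O)(=O)c4ccccc4)C[C@@H]3C(=O)NC[C@H]3CCCN3)cc2c1` gives 0.11 10^-6 cm/s
compound 2 `Cc1ccc2[nH]c(C(=O)N[C@H]3CN(S(=O)(=O)c4ccccc4)C[C@@H]3C(=O)N[C@H]3CCCN(C)C3)cc2c1` gives 0.3 10^-6 cm/s
compound 3 `Cc1ccc2[nH]c(C(=O)N[C@H]3CN(S(=O)(=O)c4ccccc4)C[C@@H]3C(=O)N[C@H]3CCCNC3)cc2c1` gives 0.04 10^-6 cm/s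

Compound 3 stands lowest of the three, and the gaps to both others lie beyond the scatter. It is reached by a 2.8-fold lower number from compound 1 to compound 3 (0.44 log units; beyond the scatter) and by a 7.5-fold lower number from compound 2 to compound 3 (0.88 log units; beyond the scatter) in the record.

Compound 4 `Cc1csc(C(=O)N[C@H]2CN(S(=O)(=O)c3ccccc3)C[C@@H]2C(=O)N[C@H]2CCCNC2)n1` has 4-methyl-1,3-thiazol-2-yl in place of 5-methyl-1H-indol-2-yl on a carbonyl carbon. Among the measured compounds shown here, no measured step touches that place. The three measured steps concern only the substituent on an amide-type nitrogen and the methyl on an amine nitrogen in a ring. Alongside the two already named, the third is a 2.7-fold higher number from compound 1 to compound 2 (0.44 log units; beyond the scatter) and all three are modest. They therefore offer a scale for this assay in this series and no direct guide to the new group.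

A modest rise is expected, since compound 3 already holds the lowest number (0.04 10^-6 cm/s) of the series. The expected step is a 2.5-fold higher number from compound 3 to compound 4 (0.40 log units; beyond the scatter) and it remains uncertain. Compound 4 is estimated at 0.1 10^-6 cm/s with a range from 0.03 10^-6 cm/s to 0.35 10^-6 cm/s expected.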

Compound 4, apparent permeability: 0.18 10^-6 cm/s
Estimate against measurement, compound 4: 1.8-fold (0.26 log units) below, and the stated range covers the measured number.
By their numbers in this assay, from the lowest: compound 3; then compounds 1, 4 and 2 (each within the scatter of the next, the first and the last beyond it).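

In this assay, among the compounds shown here, exchanging 5-methyl-1H-indol-2-yl for 4-methyl-1,3-thiazol-2-yl on a carbonyl carbon gives a 4.5-fold higher number from compound 3 to compound 4 (0.65 log units; beyond the scatter), which is the first measured step at this place and shows that the number responds to the group here as well as to the substituent on the amide-type nitrogen. The change is a single step with several differences at once: the entering group has fewer heavy atoms, fewer hydrogen-bond donors and more hydrogen-bond acceptors than the group it replaces, and it brings in sulfur, so the result cannot assign the rise to any one of these. Nothing among the data shown accounts for the rise.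

The compounds shown leave open whether a step of this size would recur with 1-methylpiperidin-3-yl or (pyrrolidin-2-yl)methyl on the amide-type nitrogen, since the new group appears here only with piperidin-3-yl. They also leave open how a 1,3-oxazol-2-yl group, a 1,3-thiazol-2-yl group without the methyl, or a plain phenyl group on the same carbonyl carbon would read in this assay.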